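The source may hold more compounds than are shown below. What is called first, only, known or untested is meant among the compounds shown, and "the series" means these compounds.

Measured so far:
- Compound 1, `Cn1ncc(Cl)c1-c1cc(C(=O)N[C@@H]2CN[C@H](CCn3cncn3)C[C@H]2c2ccc(Cl)c(Cl)c2)oc1Cl`, gives 4.47 nM in an assay for inhibition of RAC-alpha serine/threonine-protein kinase (Homo sapiens), read by HTRF, with a stated time of 1 h; on this read-out higher numbers stand for weaker inhibition and lower numbers for stronger inhibition.
- Compound 2, `CN(C)CC[C@@H]1C[C@@H](c2ccc(Cl)c(Cl)c2)[C@H](NC(=O)c2cc(-c3c(Cl)cnn3C)c(Cl)o2)CN1`, gives 3.4 nM in this assay.

Within the data shown here, compound 2 holds the lowest of the two numbers, and its only neighbour is compound 1: a 1.3-fold lower number from compound 1 to compound 2 (0.12 log units; within the scatter). Compound 3, `Cn1ncc(Cl)c1-c1cc(C(=O)N[C@@H]2CN[C@H](CCN3CCCC3)C[C@H]2c2ccc(Cl)c(Cl)c2)oc1Cl`, is the next step: pyrrolidin-1-yl in place of dimethylamino on a saturated chain carbon, two bonds along the chain from a saturated ring carbon. Among the measured compounds shown here, the one measured step exchanged a group at the same place and stayed within the scatter, so from compound 2 to compound 3 no step beyond the scatter is expected, in either direction. Compound 3 is therefore expected to give 3.5 nM, between 1.5 nM and 8 nM, a step of a 1.0-fold higher number from compound 2 to compound 3 (0.01 log units; within the scatter).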

Compound 3, half-maximal inhibitory concentration: 6.41 nM
Beside the measured number, compound 3's estimate is 1.8-fold (0.26 log units) below it; measured number inside the range.
By their numbers in this assay, from the lowest: compounds 2, 1 and 3 (each within the scatter of the next).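

Pyrrolidin-1-yl, which brings a five-membered non-aromatic ring, can stand in place of dimethylamino (a 1.9-fold higher number from compound 2 to compound 3 (0.28 log units; within the scatter)) or of 1H-1,2,4-triazol-1-yl (a 1.4-fold higher number from compound 1 to compound 3 (0.16 log units; within the scatter)) and stay within the scatter in this read-out (this assay). All three groups on this saturated chain carbon therefore give numbers that cannot be told apart, so this position has so far accepted both an open and a ring-closed amine. No measurement bears on why this is so. As far as these compounds go, it remains open whether a larger ring amine such as morpholine or piperidine, a carboxylic acid or a longer chain would keep this level. From the compounds shown here alone, a primary amine at this place is equally open.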